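Aryl exchange at the saturated ring carbon: compound 4

This account rests on a few compounds, and the source may have more. Where it says the series, first, only, none or still open, it means among the compounds named here.

Measured so far:
- compound 1 `COC(=O)c1cccc(C2C(C(=O)O)=C(C)N=C(C)/C2=C(/O)OC/C=C/c2ccccc2)c1` gives 4400 nM
- compound 2 `CC1=NC(C)=C(C(=O)O)C(c2cccc(C)c2)/C1=C(\O)OC/C=C/c1ccccc1` gives 76 nM
- compound 3 `CC1=NC(C)=C(C(=O)O)C(c2cccc(I)c2)/C1=C(\O)OC/C=C/c1ccccc1` gives 13 nM

In a functional assay on thoracic aorta for inhibition of Voltage-gated L-type calcium channel (Rattus norvegicus) (on this read-out lower numbers stand for stronger inhibition and higher numbers for weaker inhibition), compound 3 stands lowest of the three numbers; its nearest neighbour is compound 2, seen in a 5.8-fold lower number from compound 2 to compound 3 (0.77 log units; beyond the scatter), and the furthest is compound 1, seen in a 340-fold lower number from compound 1 to compound 3 (2.53 log units; beyond the scatter). Both steps lie beyond the scatter, so compound 3 is the strongest inhibitor measured here.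

Compound 4 `CC1=NC(C)=C(C(=O)O)C(c2ccsc2)/C1=C(\O)OC/C=C/c1ccccc1` differs from compound 3 by thiophen-3-yl in place of 3-iodophenyl on a saturated ring carbon. Among the compounds with values here, no measured step exchanges the aromatic ring itself; the three known steps, a 58-fold lower number from compound 1 to compound 2 (1.76 log units; beyond the scatter), a 340-fold lower number from compound 1 to compound 3 (2.53 log units; beyond the scatter) and a 5.8-fold lower number from compound 2 to compound 3 (0.77 log units; beyond the scatter), all alter only the group carried on that ring. They bear on the present change indirectly: the ring that enters carries no iodo, and the iodo was worth a modest step in a 5.8-fold lower number from compound 2 to compound 3 (0.77 log units; beyond the scatter). Within the data shown here, that gain is the part most likely to be lost, while the large penalty seen with methoxycarbonyl in compound 1 has no counterpart in thiophen-3-yl.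

A modest step upward is therefore expected, a 6.9-fold higher number from compound 3 to compound 4 (0.84 log units; beyond the scatter), placing compound 4 nearer compound 2 than compound 3. Compound 4 is estimated at 90 nM, with a range from 20 nM to 450 nM.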

Compound 4, half-maximal inhibitory concentration: 44 nM
Compound 4: middle estimate off by 2.0-fold (0.31 log units), on the high side; measured number inside the range.
By their numbers in this assay, from the lowest: compound 3; then compounds 4 and 2 (each within the scatter of the next); then compound 1.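

In this assay the aromatic ring on the saturated ring carbon can itself be exchanged, not only the group it carries. Thiophen-3-yl, a five-membered aromatic ring with no further group, stays far from the weak end of the series (with a 100-fold lower number from compound 1 to compound 4 (2.00 log units; beyond the scatter)), so a six-membered carbon ring is not required at this position in these compounds. The 3-iodophenyl group keeps a real lead over thiophen-3-yl (with a 3.4-fold higher number from compound 3 to compound 4 (0.53 log units; beyond the scatter)), whereas the exchange for 3-methylphenyl cannot be told apart from repeat scatter (with a 1.7-fold lower number from compound 2 to compound 4 (0.24 log units; within the scatter)), so swapping the ring type costs no more here than the difference between iodo and methyl on the phenyl ring.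

Nothing among the data shown accounts for these differences between the rings.

Open, as far as these compounds go, is whether an iodo or methyl group on the thiophene ring would recover the lead held by compound 3. Also open, from the compounds shown here alone, is how other rings at this carbon compare with thiophen-3-yl, such as thiophen-2-yl, furan-3-yl or pyridin-3-yl, and whether a basic amine on the ring would be tolerated as poorly as methoxycarbonyl.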